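This account rests on a few compounds, and the source may have more. Where it says the series, first, only, none or still open, it means among the compounds named here.

Compound 1 `CC(CSc1nnc(-c2ccncc2)s1)C(=O)Nc1c(Cl)cccc1Cl`: in an ADME assay on HepG2 cells (Homo sapiens) for cytotoxicity, with a stated time of 3 days (on this read-out higher numbers stand for lower toxicity in this test and lower numbers for higher toxicity in this test), compound 1 gives > 50000 nM, which is a limit of the assay and not a number.
Compound 2 `CC(CSc1nnc(-c2ccncc2)s1)C(=O)Nc1ccc(Cl)cc1`: in this assay compound 2 gives > 50000 nM, again a limit of the assay rather than a number.
Compound 3 `CC(CSc1nnc(-c2ccncc2)s1)C(=O)NCc1ccc(Cl)cc1`: in this assay compound 3 gives "not determined" (no result reported).

All three compounds share one core and differ only in the group on the amide-type nitrogen. Compound 1 and compound 2 differ by 4-chlorophenyl in place of 2,6-dichlorophenyl there, and the step that the two limits leave unreadable from compound 1 to compound 2 cannot be read, since both ends sit at the limit. For the measured compounds named here, the only firm evidence is therefore (the limit of > 50000 nM in this assay, at which 2 of the 3 values shown sit). Going by the values given here, compound 3 stands apart from these numbers: no result exists for it, so no measured step leads to it or away from it.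

Compound 4 `CC(CSc1nnc(-c2ccncc2)s1)C(=O)Nc1ccccc1` differs from compound 3 by phenyl in place of 4-chlorobenzyl on an amide-type nitrogen. Among the compounds with values here, no measured step bears on this change, so no size or direction of step can be stated for it; because the limit of > 50000 nM in this assay, at which 2 of the 3 values shown sit, shows both measured compounds reaching the limit, the expectation is that compound 4 behaves like them. Compound 4 is estimated at 50000 nM, with an expected range from 20000 nM to 100000 nM.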

Compound 4, half-maximal cytotoxic concentration: > 50000 nM
Compound 4 ended at the assay's limit; the forecaster's own chance of this, stated with the estimate: 75%; the middle value sits exactly at the limit.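

Compound 4 sits at the same limit as compound 1 and compound 2, so neither step from those two compounds to compound 4 can be read: the limit of > 50000 nM in this assay, at which 3 of the 4 values shown sit. The compounds shown leave open how the groups on the amide-type nitrogen rank in this assay, and where compound 3 stands.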